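A larger ring group in place of a smaller one

The source may report more compounds than this note shows. Statements on the series, on what has been measured and on what is new or still open speak of the compounds shown alone.

In a physicochemical assay for lipophilicity, measured as octanol-water partition, at pH 7.4 (on this read-out higher numbers stand for higher lipophilicity and lower numbers for lower lipophilicity), compound 3 `O=C(N[C@H]1CN(S(=O)(=O)c2ccccc2)C[C@@H]1C(=O)NC[C@@H]1CCCN1)c1cc(-c2ccccc2Cl)on1` gives 1.5. That lies within the scatter of compound 1 `Cc1ccc2[nH]c(C(=O)N[C@H]3CN(S(=O)(=O)c4ccccc4)C[C@@H]3C(=O)N[C@H]3CCCNC3)cc2c1` at 1.3, and clearly under compound 2 `O=C(N[C@H]1CN(S(=O)(=O)c2ccccc2)C[C@@H]1C(=O)N[C@H]1CCCNC1)c1cc(-c2ccccc2Cl)on1` at 1.9. Compound 4 `O=CN1CCC[C@H](NC(=O)[C@H]2CN(S(=O)(=O)c3ccccc3)C[C@@H]2NC(=O)c2cc(-c3ccccc3Cl)on2)C1` differs from compound 3 on an amide-type nitrogen: a group of 8 heavy atoms (6 carbon, 1 nitrogen, 1 oxygen; one six-membered non-aromatic ring with 1 hetero atom) in place of a group of 6 heavy atoms (5 carbon, 1 nitrogen; one five-membered non-aromatic ring with 1 hetero atom), on an amide-type nitrogen. The most relevant guide is a number 0.40 log units lower from compound 2 to compound 3 (beyond the scatter), a modest step at that same place, where (pyrrolidin-2-yl)methyl replaced piperidin-3-yl. Compound 4 regains a six-membered non-aromatic ring, so that step points upward here. The modest step of a number 0.60 log units higher from compound 1 to compound 2 (beyond the scatter) was made on a carbonyl carbon and bears less on this change. The expected step is a number 1.00 log units higher from compound 3 to compound 4 (beyond the scatter), upward and beyond the scatter. For compound 4 the estimate is 2.5, with an expected range of 1.9 to 3.1.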

Compound 4, distribution coefficient: 3.1
Compound 4: middle estimate off by 0.60 log units, on the low side, within the range that was stated.
By their numbers in this assay, from the lowest: compounds 1 and 3 (each within the scatter of the next); then compound 2; then compound 4.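

Among the compounds shown here, at this amide-type nitrogen, the side group can shift this assay further than the earlier compounds showed, with the full exchange giving a number 1.60 log units higher from compound 3 to compound 4 (beyond the scatter). A single change on the ring, formyl in place of hydrogen on the amine nitrogen, gives a number 1.20 log units higher from compound 2 to compound 4 (beyond the scatter). The number here therefore depends on what sits on that ring nitrogen, not only on which ring is present. Nothing measured here gives a reason for these rises. From the compounds shown here alone, whether acetyl or methyl on that ring nitrogen would move the number as far remains open.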